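Nitro for methoxy on the pendant aryl ring

The compounds below may be only part of what the source reports. "The series", "measured", "known", "first", "only" and "open" are said of these compounds alone.

Measured so far:
compound 1 `C[C@H]1CC[C@@H]2[C@@H](OC(=O)[C@]23CC(c2ccc([N+](=O)[O-])cc2)=NO3)[C@]2(C)C(=O)C=C[C@@]12O` in a physicochemical assay for lipophilicity; a lower number here means a more polar compound, a higher number a more lipophilic compound: 1.37
compound 2 `COc1ccc(C2C[C@@]3(ON2c2ccccc2)C(=O)O[C@@H]2[C@H]3CC[C@H](C)[C@]3(O)C=CC(=O)[C@@]23C)cc1` in this assay: 3.25

Compound 2 holds the higher of the two values in this assay; the nearest number, that of compound 1, sits well below it, beyond the scatter. The two structures differ in more than one place, so their values are noted side by side without a step being drawn between them.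

Compound 3 `C[C@H]1CC[C@@H]2[C@@H](OC(=O)[C@]23CC(c2ccc([N+](=O)[O-])cc2)N(c2ccccc2)O3)[C@]2(C)C(=O)C=C[C@@]12O` has not yet been measured in this assay. It differs from compound 2 by nitro in place of methoxy on an aromatic carbon. Going by the values given here, no measured pair isolates that exchange. A step of this kind is expected to be small, likely a slight fall or none beyond the scatter, since compound 2 gives 3.25 and the rest of the molecule is unchanged. Compound 3 is therefore expected to land at 3, within 2.5 to 3.5, the expected step being a number 0.25 log units lower from compound 2 to compound 3 (within the scatter).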

Compound 3, partition coefficient: 3.15
For compound 3 the middle estimate is 0.15 log units below the measured one; the range from low to high includes it.
By their numbers in this assay, from the lowest: compound 1; then compounds 3 and 2 (each within the scatter of the next).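

Going by these compounds alone, compound 2 and compound 3 form the only pair here that isolates nitro in place of methoxy on an aromatic carbon para to a large group, and the exchange gives a number 0.10 log units lower from compound 2 to compound 3 (within the scatter) in this assay on the shared core. At this position, then, 4-methoxyphenyl and 4-nitrophenyl cannot be told apart by this read-out, even though the two groups differ in heavy atoms and hydrogen-bond acceptors. Nothing on hand offers a reason for this result.

As far as these compounds go, whether an amine or a carboxylic acid on the same aromatic carbon would also stay within the scatter of compound 2 remains open. A single pair also cannot show whether the same exchange would behave alike on the core of compound 1.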